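The compounds below may be only part of what the source reports. "The series", "measured", "known", "first", "only" and "open" are said of these compounds alone.

In an assay on CHO-K1 cells for antagonist activity at transient receptor potential cation channel subfamily V member 1 (Homo sapiens), read by FLIPR and calcium flux, with a stated time of 6 min (a lower number here means a stronger inhibitor, a higher number a weaker inhibitor), compound 1 `CC(C)(C)c1cc(CNC(=O)Nc2cccc3[nH]ncc23)n(-c2cccc(Cl)c2)n1` gives 0.6 nM and compound 2 `CC(C)(C)c1cc(CNC(=O)Nc2cccc3[nH]ncc23)n(-c2cccc(F)c2)n1` gives 1.3 nM. Compound 3 `CC(C)(C)c1ccc(-n2nc(C(C)(C)C)cc2CNC(=O)Nc2cccc3[nH]ncc23)cc1` gives 40 nM, the highest of the three numbers and so the weakest inhibitor of the set. Compound 4 `CC(C)(C)c1cc(CNC(=O)Nc2cccc3[nH]ncc23)n(-c2ccc(F)c(Cl)c2)n1` differs from compound 3 in one place: 3-chloro-4-fluorophenyl in place of 4-(tert-butyl)phenyl on an aromatic nitrogen. For the measured compounds named here, two measured steps bear on this. Each exchanges the same 4-(tert-butyl)phenyl for a halogen-bearing phenyl: a 67-fold higher number from compound 1 to compound 3 (1.82 log units; beyond the scatter) and a 31-fold higher number from compound 2 to compound 3 (1.49 log units; beyond the scatter). Read in reverse, both point to a far lower number once a halogen-bearing phenyl sits on the aromatic nitrogen. The step of a 2.2-fold higher number from compound 1 to compound 2 (0.34 log units; beyond the scatter) shows that chloro and fluoro differ only modestly. Since compound 4 carries both halogens, a large drop in the number is expected: a 50-fold lower number from compound 3 to compound 4 (1.70 log units; beyond the scatter). Compound 4 is therefore estimated at 0.8 nM, within 0.3 nM to 2.5 nM.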

Compound 4, inhibition constant: 0.5 nM
The estimate for compound 4 lay 1.6-fold (0.20 log units) above the measured number; the measured number falls inside the stated range.
By their numbers in this assay, from the lowest: compounds 4 and 1 (each within the scatter of the next); then compound 2; then compound 3.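

In this assay, the large step of an 80-fold lower number from compound 3 to compound 4 (1.90 log units; beyond the scatter) shows that a phenyl carrying two halogens works on the aromatic nitrogen as well as one carrying a single halogen does. Against 3-fluorophenyl, the new group gives a 2.6-fold lower number from compound 2 to compound 4 (0.41 log units; beyond the scatter) as a modest gain. Fluoro in place of hydrogen on the chlorophenyl gives a 1.2-fold lower number from compound 1 to compound 4 (0.08 log units; within the scatter) and so no change that can be told apart, which means this extra fluoro neither helps nor harms here.

Going by these compounds, whether an amine or a methoxy group on this phenyl ring would keep the number this low stays open. No measurement here explains why these groups differ.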